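Aryl variation on the sulfur arm of a nucleoside series

A few compounds are considered here, and "the series" means these few. Any claim that something is new, unique, unknown or untested is made for them only; others in the source may bear on it.

Three compounds share one core and differ only in the aryl group on the saturated chain carbon bound to a sulfur. Compound 1 `OC[C@H]1O[C@@H](n2cnc3c(SCc4cccc(Cl)c4)ncnc32)[C@H](O)[C@@H]1O` gives 18.2 nM in an assay on isolated protein for inhibition of Equilibrative nucleoside transporter 1 (Homo sapiens); a higher number here means a weaker inhibitor, a lower number a stronger inhibitor. Compound 2 `OC[C@H]1O[C@@H](n2cnc3c(SCc4ccc(Br)cc4)ncnc32)[C@H](O)[C@@H]1O` gives 11.5 nM, and compound 3 `Cc1ccc(CSc2ncnc3c2ncn3[C@@H]2O[C@H](CO)[C@@H](O)[C@H]2O)cc1` gives 15.1 nM. The steps are a 1.6-fold lower number from compound 1 to compound 2 (0.20 log units; within the scatter) and a 1.2-fold lower number from compound 1 to compound 3 (0.08 log units; within the scatter), with a 1.3-fold higher number from compound 2 to compound 3 (0.12 log units; within the scatter) between the two para-substituted analogues. Compound 2 holds the lowest of the three numbers, but its gaps to compound 3 and to compound 1 are both within the scatter, so no order among the three is established.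

Compound 4 `Cc1cc(C)c(CSc2ncnc3c2ncn3[C@@H]2O[C@H](CO)[C@@H](O)[C@H]2O)c(C)c1` is not yet measured. The change from compound 2 is 2,4,6-trimethylphenyl in place of 4-bromophenyl on a saturated chain carbon bound to a sulfur. All three measured steps bear on it, since each swaps one aryl group for another at the same place, and none of them moved the number beyond the scatter. The trimethylphenyl is a larger departure than any swap seen so far, and nothing measured tells how three methyl groups behave here. The expectation is therefore a step of about a 1.9-fold higher number from compound 2 to compound 4 (0.28 log units; within the scatter), with a wide range. Compound 4 is expected to give about 22 nM in this assay, between 8 nM and 60 nM.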

Compound 4, inhibition constant: 1910 nM
Compound 4: middle estimate off by 87-fold (1.94 log units), on the low side; the whole stated range lies below it.
By their numbers in this assay, from the lowest: compounds 2, 3 and 1 (each within the scatter of the next); then compound 4.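

The place on the saturated chain carbon bound to a sulfur tolerates some aryl swaps but not all: in this assay, 3-chlorophenyl, 4-bromophenyl and 4-methylphenyl stay within the scatter of one another, yet the 2,4,6-trimethylphenyl group produces a 170-fold higher number from compound 2 to compound 4 (2.22 log units; beyond the scatter) and a 100-fold higher number from compound 1 to compound 4 (2.02 log units; beyond the scatter). The closest comparison is a 130-fold higher number from compound 3 to compound 4 (2.10 log units; beyond the scatter), where both aryl groups carry methyl and the 2,4,6-trimethylphenyl simply has more of it, so methyl substitution on this ring is not uniformly tolerated at this place. No measurement at hand accounts for this large rise in the number.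

Still open, going by these compounds, is whether the rise requires all the methyl groups of the 2,4,6-trimethylphenyl or follows from only some of them. Also open, on these data alone, is how this place responds to groups of a different kind, such as an amine or a carboxylic acid on the aryl ring, or a longer chain carrying the aryl ring on the sulfur.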